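Swapping the Ring on the Core Nitrogen

The compounds below may be only part of what the source reports. "The series", "measured", "known", "first", "only" and "open" are said of these compounds alone.

Compound 1, `COc1ccccc1-n1nc(C2CC(C)(C)OC(C)(C)C2)cc1-c1ccc(Cl)cc1`: 1 nM
Compound 2, `COc1ccccc1-n1nc(C2CC(C)(C)OC(C)(C)C2)cc1-c1ccc(C)nc1`: 6 nM

In an assay on HEK293 cells for inhibition of Voltage-dependent N-type calcium channel subunit alpha-1B (Homo sapiens), read by fluorescence and calcium flux, with a stated time of 5 min (on this read-out higher numbers stand for weaker inhibition and lower numbers for stronger inhibition), compound 1 gives 1 nM, the lower of the two numbers. Compound 2 gives 6 nM; the change is a 6.0-fold higher number from compound 1 to compound 2 (0.78 log units; beyond the scatter). Compound 3, `CC1(C)CC(c2cc(-c3ccc(Cl)cc3)n(-c3ccncc3)n2)CC(C)(C)O1`, differs from compound 1 by pyridin-4-yl in place of 2-methoxyphenyl on an aromatic nitrogen. Within the data shown here, no measured step touches this nitrogen; the only one, a 6.0-fold higher number from compound 1 to compound 2 (0.78 log units; beyond the scatter), exchanged a carbon-only ring for a nitrogen-containing ring elsewhere and cost a modest amount, so a modest rise is expected here too. Compound 3 is expected to give 5 nM, between 1 nM and 25 nM. The expected step is a 5.0-fold higher number from compound 1 to compound 3 (0.70 log units; beyond the scatter).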

Compound 3, half-maximal inhibitory concentration: 7 nM
The estimate for compound 3 lay 1.4-fold (0.15 log units) below the measured number; measured number inside the range.
By their numbers in this assay, from the lowest: compound 1; then compounds 2 and 3 (each within the scatter of the next).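

In this assay, the ring on the aromatic nitrogen also matters: pyridin-4-yl in place of 2-methoxyphenyl gives a 7.0-fold higher number from compound 1 to compound 3 (0.85 log units; beyond the scatter). A change at this second position therefore also raises the number, although compound 3 still gives 7 nM. Nothing available here explains this rise. The swap removes the methoxy group and brings in a ring nitrogen at once, and the compounds shown cannot separate these two changes. A plain phenyl ring on this nitrogen would help to tell them apart.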